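Methyl for Chloro on the Lactam Aryl Ring

The source may report more compounds than this note shows. Statements on the series, on what has been measured and on what is new or still open speak of the compounds shown alone.

The set comprises three measured compounds and one that awaits measurement, all sharing one core. Compound 1 `O=C1CC(c2nc(-c3cccc(Cl)c3)no2)CN1c1cccc(Cl)c1` carries chloro on both aryl rings. In an in vitro functional assay on HEK293-A cells for positive allosteric modulation of metabotropic glutamate receptor 5 (Homo sapiens), read by FLIPR and calcium flux (on this read-out lower numbers stand for an effect already at smaller amounts and higher numbers for an effect only at larger amounts of compound), compound 1 gives > 10000 nM, which is a limit of the assay rather than a number. Compound 1 therefore stands at the limit of > 10000 nM in this assay, at which 2 of the 3 values shown sit, the position shared by most of the values in hand. Compound 2 `O=C1CC(c2nc(-c3cccc(C(F)(F)F)c3)no2)CN1c1ccc(F)cc1` likewise gives only a limit, > 10000 nM, in this assay. Among the measured compounds shown here, compound 3 `Cc1ccc(N2CC(c3nc(-c4cccc(C)c4)no3)CC2=O)cc1`, which bears methyl on both aryl rings, is the one compound that gives a number in this assay, 1300 nM.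

Compound 4 `Cc1cccc(N2CC(c3nc(-c4cccc(Cl)c4)no3)CC2=O)c1` is the one not yet measured. It differs from compound 1 in a single place: methyl in place of chloro on an aromatic carbon. The aryl ring on the oxadiazole keeps its chloro.

For the measured compounds named here, no step between two measured compounds is available, so the size of the change must be judged from the values alone. Going by the values given here, compound 3, the one member with methyl on the lactam aryl ring, is the one that gives a number, so a step toward smaller amounts beyond the scatter is expected, estimated as an at least 2.5-fold lower number from compound 1 to compound 4 (0.39 log units; beyond the scatter). For compound 4 in this assay a value of about 4000 nM is estimated, expected to lie between 1200 nM and 14000 nM.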

Compound 4, half-maximal effective concentration: > 10000 nM
Compound 4 gave a limit, no number (the forecaster's own chance of this, stated with the estimate: 35%); at least 2.5-fold (0.39 log units) between middle value and limit.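

Compound 1 and compound 4 each give only a limit in this assay, so no step between them can be read: the limit of > 10000 nM in this assay, at which 3 of the 4 values shown sit.

The compounds shown leave open how large the change from 3-chlorophenyl to 3-methylphenyl is here, and whether methyl on both aryl rings is what sets apart compound 3, the only one with a number.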